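This account rests on a few compounds, and the source may have more. Where it says the series, first, only, none or still open, it means among the compounds named here.

Series notes. Among the measured compounds shown here, compound 1 `COc1cc(C)cc(-c2c(-c3ccnc(-c4ccc(C(C)=O)cc4)c3)cnn2CC#N)c1` and compound 2 `COc1cc(C)cc(-c2nn(CC#N)cc2-c2ccnc(-c3ccc(N(C)C)cc3)c2)c1` are the two measured members. In a functional assay on SK-OV-3 cells (Homo sapiens) for cytotoxicity, read by sulforhodamine B assay, with a stated time of 48 h, tested at 1 uM (a higher number here means a weaker effect of the compound at the concentration tested, a lower number a stronger effect), compound 1 gives 19%, the higher of the two numbers; in this assay compound 2 gives -24%, and the gap between them is beyond the scatter. The two differ in more than one place, so nothing single is attached to that gap.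

Compound 3 `COc1cc(C)cc(-c2c(-c3ccnc(-c4ccc(N(C)C)cc4)c3)cnn2CC#N)c1` is not yet measured. It differs from compound 1 in one place: dimethylamino in place of acetyl on an aromatic carbon. Compound 3 thereby carries the same 4-(dimethylamino)phenyl as compound 2, on a core that matches compound 1.

For the step from compound 1 to compound 3 a move to a lower number is expected, with an estimated size of a number 29 percentage points lower from compound 1 to compound 3 (beyond the scatter), because compound 2 gives -24% with the same entering group. For compound 3 an estimated this assay read-out of -10% is expected, within a range from -45% to 25%.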

Compound 3, a percentage reported as activity, at one concentration (the size of the read-out at that concentration, not a potency): 36%
Beside the measured number, compound 3's estimate is 46 percentage points below it; measured number outside the range, above it.
By their numbers in this assay, from the lowest: compound 2; then compound 1; then compound 3.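

In this assay, dimethylamino in place of acetyl on an aromatic carbon, para to a large group, gives a number 17 percentage points higher from compound 1 to compound 3 (beyond the scatter). Among the compounds shown here, this is the first single-place step: on the core of compound 1 the position responds to this change, and the effect at the concentration tested is weaker with dimethylamino than with acetyl. Compound 2 carries the same 4-(dimethylamino)phenyl and gives -24%, while compound 3 gives 36%, so that group alone does not fix the read-out across these compounds.

No measurement shown bears on the reason for this step. As far as these compounds go, whether a primary amine or a carboxylic acid in this place would give a higher or a lower number remains open, as does the effect of acetyl on the core of compound 2.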